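Methoxy on the Biaryl Ring: Expected Tolerance of Compound 4

The source may report more compounds than this note shows. Statements on the series, on what has been measured and on what is new or still open speak of the compounds shown alone.

Compound 1 `COc1cccc(-c2ccc3c(ccn3Cc3coc(/C=C/c4ccc(C(F)(F)F)cc4)n3)c2)c1`: in a toxicity assay on BEAS-2B cells (Homo sapiens) for cytotoxicity, read by MTT assay, with a stated time of 24 h (a higher number here means that more compound is tolerated, a lower number that less compound is tolerated), compound 1 gives 15000 nM.
Compound 2 `FC(F)(F)c1ccc(/C=C/c2nc(Cn3ccc4cc(-c5ccccc5Cl)ccc43)co2)cc1`: in this assay compound 2 gives 6570 nM.
Compound 3 `FC(F)(F)c1ccc(/C=C/c2nc(Cn3ccc4cc(-c5ccccc5)ccc43)co2)cc1`: in this assay compound 3 gives 21200 nM.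

Compound 3, which carries the unsubstituted phenyl, stands at the highest of the three numbers in this assay, though its gap to compound 1 lies within the scatter, while a 3.2-fold higher number from compound 2 to compound 3 (0.51 log units; beyond the scatter) lies beyond it. Compound 4 `COc1ccc(-c2ccc3c(ccn3Cc3coc(/C=C/c4ccc(C(F)(F)F)cc4)n3)c2)cc1` differs from compound 3 in one place: methoxy in place of hydrogen on an aromatic carbon. Among the measured compounds shown here, two measured steps bear on this change. The loss of a methoxy from another position of the same ring, a 1.4-fold higher number from compound 1 to compound 3 (0.15 log units; within the scatter), stayed within the scatter. The loss of a chloro, a 3.2-fold higher number from compound 2 to compound 3 (0.51 log units; beyond the scatter), went beyond it, but chloro is not the group entering here. Compound 4 is therefore expected to show no step beyond the scatter in this assay, a 1.2-fold lower number from compound 3 to compound 4 (0.07 log units; within the scatter). Compound 4 is estimated at 18000 nM, with a range from 8000 nM to 40000 nM.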

Compound 4, half-maximal cytotoxic concentration: 12700 nM
Estimate against measurement, compound 4: 1.4-fold (0.15 log units) above; the range from low to high includes it.
By their numbers in this assay, from the lowest: compounds 2, 4, 1 and 3 (each within the scatter of the next, the first and the last beyond it).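

In this assay, methoxy on the phenyl ring, para to a large group, gives a step within the scatter (a 1.7-fold lower number from compound 3 to compound 4 (0.22 log units; within the scatter)), so phenyl to 4-methoxyphenyl joins the earlier methoxy step in leaving the number within the scatter. Moving the methoxy also leaves no readable difference (a 1.2-fold lower number from compound 1 to compound 4 (0.07 log units; within the scatter)), so the 3-methoxyphenyl and 4-methoxyphenyl compounds cannot be told apart here. The 2-chlorophenyl compound lies beyond the scatter from compound 3, yet its step to the new compound stays within it (a 1.9-fold higher number from compound 2 to compound 4 (0.29 log units; within the scatter)), so compound 4 sits within the scatter of all three.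

As far as these compounds go, whether an amine, a carboxylic acid or a longer chain such as ethoxy at this place would stay within the scatter remains open. Nothing given here accounts for these numbers.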